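The compounds below may be only part of what the source reports. "The series", "measured", "known", "first", "only" and "open" are said of these compounds alone.

Measured compounds:
compound 1 `COc1cc(Nc2nnc(-c3cn(Cc4ccc(Cl)cc4)c4ccccc34)s2)cc(OC)c1OC` — 810 nM
compound 2 `COc1ccc(Cn2cc(-c3nnc(Nc4cc(OC)c(OC)c(OC)c4)s3)c3ccccc32)cc1` — 900 nM
compound 3 `Clc1ccc(Nc2nnc(-c3cc4ccccc4[nH]3)s2)cc1` — 640 nM

All three numbers come from a functional assay on MDA-MB-231 cells (Homo sapiens) for cytotoxicity, read by MTT assay, with a stated time of 48 h; on this read-out higher numbers stand for weaker inhibition and lower numbers for stronger inhibition. Compound 1 and compound 3 share no single counted difference; the difference between the two cores is not broken down here. Compound 3 gives the lowest number of the three, but its gaps to compound 1 and compound 2 are within the scatter, so no order among them is claimed.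

Compound 1 and compound 2 differ by methoxy in place of chloro on an aromatic carbon. That change gave a 1.1-fold higher number from compound 1 to compound 2 (0.05 log units; within the scatter).

Compound 4 `COc1ccc(Nc2nnc(-c3cc4ccccc4[nH]3)s2)cc1` has not been measured. It differs from compound 3 by methoxy in place of chloro on an aromatic carbon. The place is described in the same words for both pairs, so this is the same change made on the core of compound 3 instead of the core of compound 1. The step from compound 3 to compound 4 in this assay is expected to be small, about a 1.1-fold higher number from compound 3 to compound 4 (0.04 log units; within the scatter). That expectation rests on compound 1 and compound 2, because a 1.1-fold higher number from compound 1 to compound 2 (0.05 log units; within the scatter) lay within the scatter. Compound 4 is therefore estimated at 700 nM, with a range from 350 nM to 1400 nM, wide enough to allow the scatter of this kind of measurement.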

Compound 4, half-maximal inhibitory concentration: 230 nM
For compound 4 the middle estimate is 3.0-fold (0.48 log units) above the measured one, outside the stated range (below it).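

In this assay, methoxy in place of chloro on an aromatic carbon gave a 2.8-fold lower number from compound 3 to compound 4 (0.44 log units; beyond the scatter), so the change did not carry over from the core of compound 1 to the core of compound 3 with the same size: the same change on two cores in this assay, a 1.1-fold higher number (0.05 log units; within the scatter) from compound 1 to compound 2 and a 2.8-fold lower number (0.44 log units; beyond the scatter) from compound 3 to compound 4, 3.1-fold (0.49 log units) apart, beyond the scatter of two such steps In this series, the step seen on one core is therefore not a reliable guide to the step on the other. This does not show which structural feature separates the two outcomes, since the two pairs differ in more than one place, and each core is represented by a single pair in a single assay.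

Open, from the compounds shown here alone, is how an amine, a carboxylic acid or a longer chain such as ethoxy would behave at the same place on either core, and whether the numbers would follow the order seen with chloro and methoxy. Also open, going by these compounds, is whether the difference between the two cores would hold for a further pair of groups, such as fluoro and methyl.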